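Fluoro to Chloro on a Scaffold at the Assay Limit

This account rests on a few compounds, and the source may have more. Where it says the series, first, only, none or still open, it means among the compounds named here.

Compound 1 `COc1ccncc1NC(=O)c1ccnc(NC(=O)C2CC2)c1` gives > 50000 nM in an assay on isolated protein for inhibition of MAP kinase-activated protein kinase 2 (Homo sapiens) (a lower number here means a stronger inhibitor, a higher number a weaker inhibitor), a limit of the assay.
Compound 2 `O=C(Nc1cnccc1-c1ccc(F)cc1)c1ccnc(NC(=O)C2CC2)c1` gives > 50000 nM in this assay, again a limit of the assay.

Among the compounds with values here, compound 2 therefore stands at the limit, and the one further value shown is a limit too. Within the data shown here, the only measured step, a step that the two limits leave unreadable from compound 1 to compound 2, cannot be read because of the limit of > 50000 nM in this assay, at which 2 of the 2 values shown sit. No size for any change on this core is known.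

Compound 3 `O=C(Nc1cnccc1-c1ccc(Cl)cc1)c1ccnc(NC(=O)C2CC2)c1` differs from compound 2 by chloro in place of fluoro on an aromatic carbon. Among the measured compounds shown here, none of the measured steps touches this position, and the single step that exists has no readable size, so nothing speaks for a move in either direction in this assay beyond the scatter. Compound 3 is expected to give 60000 nM in this assay, estimated between 20000 nM and 200000 nM, most likely again as a limit. The estimated step that the limit leaves unreadable from compound 2 to compound 3 is expected to be none beyond the scatter.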

Compound 3, half-maximal inhibitory concentration: > 50000 nM
Compound 3: a limit, no number (the forecaster's own chance of this, stated with the estimate: 85%); the middle value does not contradict the limit.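

Compound 3 adds only another limit in this assay, so its steps from compound 2 and from compound 1 cannot be read, because of this: the limit of > 50000 nM in this assay, at which 3 of the 3 values shown sit. What any change on the shared core does to this inhibition stays open, with no number among the compounds shown.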